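The compounds below may be only part of what the source reports. "The series", "measured", "known", "first", "only" and "open" are said of these compounds alone.

Measured so far:
compound 1 `Clc1ccc(-c2cc(-c3cccnc3)nc(-c3cccs3)c2)o1` — 25.8%
compound 2 `Clc1ccc(-c2cc(-c3cccnc3)nc(-c3ccsc3)c2)o1` — 0%
compound 3 `Cc1ccc(-c2cc(-c3ccc(Cl)o3)cc(-c3cccs3)n2)cc1` — 41.8%

All three were run in an assay on isolated protein for inhibition of DNA topoisomerase 1 (Homo sapiens), tested at 100 uM; a lower number here means a weaker effect, a higher number a stronger effect of the compound at the concentration tested. Compound 3 stands highest of the three, and its cores differ from those of compound 1 by 4-methylphenyl in place of pyridin-3-yl on an aromatic carbon, a change that gave a number 16 percentage points higher from compound 1 to compound 3 (beyond the scatter).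

The change thiophen-3-yl in place of thiophen-2-yl on an aromatic carbon occurs twice in the series. Where it is measured it gave a number 25.8 percentage points lower from compound 1 to compound 2 (beyond the scatter). Compound 4 `Cc1ccc(-c2cc(-c3ccc(Cl)o3)cc(-c3ccsc3)n2)cc1` is not yet measured; it differs from compound 3 by thiophen-3-yl in place of thiophen-2-yl on an aromatic carbon. This is the same kind of change, not the same: in compound 1 the place is meta to a pyridin-3-yl group, in compound 3 it is meta to a 4-methylphenyl group.

For compound 4 the step is expected to be a number 26.8 percentage points lower from compound 3 to compound 4 (beyond the scatter), resting on compound 1 giving a number 25.8 percentage points lower from compound 1 to compound 2 (beyond the scatter) once the change is made. Compound 4 is thus estimated at 15%, likely between 0% and 35%.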

Compound 4, a percentage reported as inhibition, at one concentration (the size of the read-out at that concentration, not a potency): 2.6%
Compound 4: the middle estimate sits 12.4 percentage points above what was measured, and the stated range covers the measured number.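

Thiophen-3-yl in place of thiophen-2-yl carries over to the second core in this assay, giving a number 39.2 percentage points lower from compound 3 to compound 4 (beyond the scatter), and the size of the step holds as well: the same change on two cores in this assay, a number 25.8 percentage points lower (beyond the scatter) from compound 1 to compound 2 and a number 39.2 percentage points lower (beyond the scatter) from compound 3 to compound 4, 13.4 percentage points apart, within the scatter of two such steps. The other change, 4-methylphenyl in place of pyridin-3-yl, gives a number 2.6 percentage points higher from compound 2 to compound 4 (within the scatter) on the thiophen-3-yl compounds, yet this step cannot be told apart from the earlier one: the same change on two cores in this assay, a number 16 percentage points higher (beyond the scatter) from compound 1 to compound 3 and a number 2.6 percentage points higher (within the scatter) from compound 2 to compound 4, 13.4 percentage points apart, within the scatter of two such steps. Two cores do not show that either change would carry to a third, and a read-out at one concentration gives no potency.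

Open, going by these compounds, is what happens when the 5-chlorofuran-2-yl group gives way to another group. Also open, on these data alone, is the effect of an amine or a carboxylic acid in place of the methyl of the 4-methylphenyl group.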